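This account rests on a few compounds, and the source may have more. Where it says the series, first, only, none or still open, it means among the compounds named here.

Measured so far in a functional assay on SH-SY5Y cells (Homo sapiens) for cytotoxicity, read by MTT assay, with a stated time of 72 h; on this read-out lower numbers stand for stronger inhibition and higher numbers for weaker inhibition:
compound 1 `O=C1c2c[n+]([O-])c3ccccc3c2C(=O)c2c1c1ccccc1n2CCCCN1CCNCC1` gives 1240 nM
compound 2 `CN(C)CCCCn1c2c(c3ccccc31)C(=O)c1c[n+]([O-])c3ccccc3c1C2=O` gives 250 nM
compound 3 `O=C1c2c[n+]([O-])c3ccccc3c2C(=O)c2c1c1ccccc1n2CCN1CCCC1` gives 520 nM

Compound 3 stands second highest of the three numbers; its nearest neighbour is compound 2, a 2.1-fold higher number from compound 2 to compound 3 (0.32 log units; beyond the scatter), and its furthest compound 1, a 2.4-fold lower number from compound 1 to compound 3 (0.38 log units; beyond the scatter).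

Compound 4 `CCCCN1CCN(CCCCn2c3c(c4ccccc42)C(=O)c2c[n+]([O-])c4ccccc4c2C3=O)CC1` is not yet measured. It differs from compound 3 as follows: 2-(4-butylpiperazin-1-yl)ethyl in place of pyrrolidin-1-yl on a saturated chain carbon, two bonds along the chain from an aromatic nitrogen. Among the compounds with values here, the steps that bear on this are a 2.4-fold lower number from compound 1 to compound 3 (0.38 log units; beyond the scatter) and a 5.0-fold lower number from compound 1 to compound 2 (0.70 log units; beyond the scatter), both modest; compound 1 also carries a piperazine on a four-carbon chain, and compound 4 adds a butyl to such a piperazine, for which no step is known. A modest upward step is therefore expected, a 1.6-fold higher number from compound 3 to compound 4 (0.21 log units; within the scatter). For compound 4 the estimate is 850 nM, range 300 nM to 2500 nM.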

Compound 4, half-maximal inhibitory concentration: 6100 nM
The estimate for compound 4 lay 7.2-fold (0.86 log units) below the measured number, outside the stated range (above it).
By their numbers in this assay, from the lowest: compound 2; then compound 3; then compound 1; then compound 4.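

In this assay, within the data shown here, butyl in place of hydrogen on an amine nitrogen in a ring gives a 4.9-fold higher number from compound 1 to compound 4 (0.69 log units; beyond the scatter) and is the first step read at this ring nitrogen, showing that substitution there shifts the number beyond the scatter. Against the two smaller amines, the steps are large: a 24-fold higher number from compound 2 to compound 4 (1.39 log units; beyond the scatter) and a 12-fold higher number from compound 3 to compound 4 (1.07 log units; beyond the scatter) place compound 4 highest of the four. No measurement at hand accounts for these steps.

Open, as far as these compounds go, is whether methyl or 2-hydroxyethyl on that ring nitrogen follows the butyl step. Also open, from the compounds shown here alone, is whether a 4-butylpiperazin-1-yl group gives a similar step on the chain of compound 3.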